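This account rests on a few compounds, and the source may have more. Where it says the series, first, only, none or still open, it means among the compounds named here.

Measured compounds:
- compound 1, `CCNC1=NCCC2(CCCCC2)S1`: 1.38
- compound 2, `FC(F)(F)c1ccc(NC2=NCCC3(CCCCC3)S2)cc1`: 2.18
- compound 3, `CC(=O)c1cccc(NC2=NCCC3(CCCCC3)S2)c1`: 2.37

All three were tested in a physicochemical assay for lipophilicity, measured as octanol-water partition, at pH 7.4; a higher number here means a more lipophilic compound, a lower number a more polar compound. Compound 1 gives 1.38, compound 2 gives 2.18 and compound 3 gives 2.37. Among these numbers compound 2 and compound 3 sit within the usual scatter of each other, so nothing separates them, while compound 1 lies clearly lower than compound 2, a gap well beyond the scatter.

The next compound, compound 4 `CC(C)c1ccc(NC2=NCCC3(CCCCC3)S2)cc1`, has not yet been measured in this assay. It comes from compound 2 by one change: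

isopropyl in place of trifluoromethyl on an aromatic carbon

For the measured compounds named here, no measured pair in this set shows this particular exchange, so its size can only be estimated. The expectation is a moderate upward step, a number 0.57 log units higher from compound 2 to compound 4 (beyond the scatter), going beyond the usual scatter. On that basis compound 4 is estimated at 2.75 in this assay, with a plausible range from 2.35 to 3.15.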

Compound 4, distribution coefficient: 1.57
Compound 4: middle estimate off by 1.18 log units, on the high side; measured number outside the range, below it.
By their numbers in this assay, from the lowest: compounds 1 and 4 (each within the scatter of the next); then compounds 2 and 3 (each within the scatter of the next).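

At this position, on an aromatic carbon para to a large group, isopropyl in place of trifluoromethyl gives a number 0.61 log units lower from compound 2 to compound 4 (beyond the scatter) in this assay. This is the first step shown at this position, and it runs downward even though the exchange swaps two groups with no ring, no hydrogen-bond donors or acceptors and no net charge, so these counts do not predict the result. Nothing available here accounts for the direction or size of this step.

The compounds shown leave open where a methyl group, a chlorine atom or a methoxy group would fall at this same position. They also leave open whether isopropyl in place of trifluoromethyl gives a similar step on another core.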